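From Amide to Sulfonamide on a Shared Core

A few compounds are considered here, and "the series" means these few. Any claim that something is new, unique, unknown or untested is made for them only; others in the source may bear on it.

Measured compounds:
compound 1, `O=C(Nc1ccc(O)c2c(=O)cc(-c3ccccc3Cl)oc12)c1ccc(Cl)c(Cl)c1`: 13000 nM
compound 2, `COc1ccc(C(=O)Nc2ccc(O)c3c(=O)cc(-c4ccccc4Cl)oc23)cc1`: 5000 nM
compound 3, `C[C@H](NC(=O)OC(C)(C)C)C(=O)Nc1ccc(O)c2c(=O)cc(-c3ccccc3Cl)oc12`: 9800 nM

These three compounds share a core and differ only in the group attached to the carbonyl carbon of the amide. In a functional assay on ID8 cells (Mus musculus) for antiproliferative activity (on this read-out higher numbers stand for weaker inhibition and lower numbers for stronger inhibition), compound 2 gives the lowest number of the three, though its gap to compound 3 lies within the scatter, so only its separation from compound 1 can be called real. The measured steps are a 2.6-fold lower number from compound 1 to compound 2 (0.41 log units; beyond the scatter), a 1.3-fold lower number from compound 1 to compound 3 (0.12 log units; within the scatter) and a 2.0-fold higher number from compound 2 to compound 3 (0.29 log units; within the scatter); all are modest or within the scatter, showing that, among these three compounds, swapping the group on the carbonyl carbon moves the number little.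

Compound 4, `O=c1cc(-c2ccccc2Cl)oc2c(NS(=O)(=O)c3ccccc3)ccc(O)c12`, is yet unmeasured. It differs from compound 2 by phenylsulfonyl in place of (4-methoxyphenyl)carbonyl on a nitrogen on an aromatic ring. Among the compounds with values here, none of the measured steps bears directly on this change: each of them kept the carbonyl and varied only what hangs on it, whereas here the carbonyl itself leaves and a sulfonyl enters. Within the data shown here, the small spread seen so far suggests the number is unlikely to move far, but with no direct precedent the uncertainty is wide. Compound 4 is therefore expected at 8000 nM, in the range 2500 nM to 25000 nM, an expected step of a 1.6-fold higher number from compound 2 to compound 4 (0.20 log units; within the scatter) in this assay.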

Compound 4, half-maximal inhibitory concentration: 9500 nM
The estimate for compound 4 lay 1.2-fold (0.07 log units) below the measured number; the range from low to high includes it.
By their numbers in this assay, from the lowest: compounds 2, 4, 3 and 1 (each within the scatter of the next, the first and the last beyond it).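

Within the data shown here, compound 4 is the first in this set to change the link itself: the earlier steps kept the carbonyl and varied what hangs on it, while here a sulfonyl takes its place on the nitrogen on an aromatic ring. In this assay this gives a 1.9-fold higher number from compound 2 to compound 4 (0.28 log units; within the scatter) and a 1.4-fold lower number from compound 1 to compound 4 (0.14 log units; within the scatter) so the sulfonyl link cannot be told apart from either amide, and compound 4 joins a set in which only compound 2 and compound 1 are separated. Each step also swaps two things at once, since the phenyl ring of compound 4 carries neither the methoxy group of compound 2 nor the two chlorines of compound 1, and no measurement at hand explains why the two links read alike here.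

The compounds shown leave open whether a 4-methoxyphenylsulfonyl group, which would compare the two links with the same ring in place, would match compound 2. They also leave open whether a small methylsulfonyl group, or a free amine on the chain of compound 3 in place of its tert-butoxycarbonyl group, would move the number any further at this nitrogen.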